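Swapping the side chain of compound 3 for a carbamoyl group

The compounds below may be only part of what the source reports. "The series", "measured", "known", "first", "only" and "open" are said of these compounds alone.

Of the compounds shown here, three sharing one core have been measured in a functional assay on the whole organism (Tail, strain ICR) with Mus musculus as the target, in the tail flick test, with a stated time of 120 min, at a dose of 25 umol/kg by the oral route; on this read-out higher numbers stand for a stronger effect at the one dose given and lower numbers for a weaker effect. Compound 1 `CC(C)[C@H](NC(=O)CN(c1nc(Cl)nc2[nH]cnc12)C1CC1)C(=O)OCc1ccccc1` gives 27.3% in this assay. Compound 2 `NC(=O)C[C@H](NC(=O)CN(c1nc(Cl)nc2[nH]cnc12)C1CC1)C(=O)O`, which carries a free acid instead of a benzyl ester, gives 17%. Compound 3 `CSCC[C@H](NC(=O)CN(c1nc(Cl)nc2[nH]cnc12)C1CC1)C(=O)OCc1ccccc1` gives 31.6%. On these numbers compound 3 and compound 1 lie within the scatter of each other, while compound 2 lies beyond the scatter below compound 3.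

The next compound, compound 4 `NC(=O)C[C@H](NC(=O)CN(c1nc(Cl)nc2[nH]cnc12)C1CC1)C(=O)OCc1ccccc1`, keeps the benzyl ester of compound 3 and changes only the side chain: carbamoyl in place of (methylsulfanyl)methyl on a saturated chain carbon, two bonds along the chain from an amide-type nitrogen and a carbonyl carbon.

One measured step speaks to this kind of change. a number 4.3 percentage points higher from compound 1 to compound 3 (within the scatter), so exchanging one side chain for another at that carbon did not move the read-out beyond the scatter. Going by the values given here, compound 2, which carries the same carbamoylmethyl side chain as compound 4 but a free acid, shows a lower number than compound 3; no single-change step links it to compound 4, so only its value can be weighed. Taken together, a small downward step is expected, a number 7.6 percentage points lower from compound 3 to compound 4 (within the scatter), likely within the scatter. Compound 4 is therefore estimated at 24%, with a range from 12% to 36%.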

Compound 4, a percentage reported as activity, at one dose (the size of the read-out at that dose, not a potency): 15.1%
Estimate against measurement, compound 4: 8.9 percentage points above; measured number inside the range.
By their numbers in this assay, from the lowest: compounds 4 and 2 (each within the scatter of the next); then compounds 1 and 3 (each within the scatter of the next).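

In this assay, the side chain on this saturated chain carbon now moves the read-out beyond the scatter: carbamoyl in place of (methylsulfanyl)methyl brings a clear drop (a number 16.5 percentage points lower from compound 3 to compound 4 (beyond the scatter)), and carbamoylmethyl in place of isopropyl brings another (a number 12.2 percentage points lower from compound 1 to compound 4 (beyond the scatter)), whereas the earlier exchange between two chains without a carbamoyl group stayed within the scatter. The ester question also looks different, since with the carbamoylmethyl side chain held fixed, benzyl in place of hydrogen on the oxygen leaves the read-out within the scatter (a number 1.9 percentage points lower from compound 2 to compound 4 (within the scatter)), so in this pair the low numbers go with the side chain and not with the free acid. No measurement at hand explains why the carbamoylmethyl chain gives the lower read-out.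

Still open, from the compounds shown here alone, is whether the drop belongs to the carbamoyl group itself or would also appear with a carboxylic acid, an amine or a longer chain ending in carbamoyl at this carbon. Going by these compounds alone, the free acid is also seen only with carbamoylmethyl, so how it behaves with isopropyl or 2-(methylsulfanyl)ethyl remains unknown.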